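The source may report more compounds than this note shows. Statements on the series, on what has been measured and on what is new or still open speak of the compounds shown alone.

Measured compounds:
- compound 1, `COc1cc(NC(=O)Nc2cccc3c(Nc4cc(OC)cc(OC)c4)ncnc23)cc(OC)c1`: 366 nM
- compound 2, `COc1cc(Nc2ncnc3c(NC(=O)Nc4ccc(Cl)cc4Cl)cccc23)cc(OC)c1`: 3060 nM

In a functional assay on RT-112 cells (Homo sapiens) for antiproliferative activity, read by MTT assay, with a stated time of 72 h (a higher number here means a weaker inhibitor of growth, a lower number a stronger inhibitor of growth), compound 1 gives 366 nM and compound 2 gives 3060 nM, so compound 2 has the highest number of the two. Among the compounds with values here, the only measured step, an 8.4-fold higher number from compound 1 to compound 2 (0.92 log units; beyond the scatter), concerns an exchange of one aryl group on the amide-type nitrogen. Compound 3, `COc1cc(Nc2ncnc3c(NC(=O)c4ccc(CN(C)C)cc4)cccc23)cc(OC)c1`, is not yet measured. Its change from compound 2 is 4-((dimethylamino)methyl)phenyl in place of (2,4-dichlorophenyl)amino on a carbonyl carbon. Within the data shown here, this alters a different part of the molecule than the measured step does, and no step in the data follows the same kind of change, so the measured step bears on it only loosely: it shows that the group on that side of the carbonyl can move the number by a modest amount. Compound 3 is therefore expected to lie near compound 2, with a step of a 2.0-fold lower number from compound 2 to compound 3 (0.31 log units; beyond the scatter) and wide uncertainty. The estimate for compound 3 is 1500 nM, between 300 nM and 7000 nM.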

Compound 3, concentration for 50% growth inhibition: 4370 nM
The estimate for compound 3 lay 2.9-fold (0.46 log units) below the measured number, within the range that was stated.
By their numbers in this assay, from the lowest: compound 1; then compounds 2 and 3 (each within the scatter of the next).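

In this assay, 4-((dimethylamino)methyl)phenyl in place of (2,4-dichlorophenyl)amino on the carbonyl carbon gives a 1.4-fold higher number from compound 2 to compound 3 (0.15 log units; within the scatter), so the two groups cannot be told apart here, although the group that leaves carries a hydrogen-bond donor and the one that enters does not. The same group in place of (3,5-dimethoxyphenyl)amino gives a 12-fold higher number from compound 1 to compound 3 (1.08 log units; beyond the scatter), which leaves compound 1, with its steps to both others beyond the scatter, as the one that stands apart among these three compounds. Nothing available explains this result.

The compounds shown leave open whether the lower number of compound 1 follows from the two methoxy groups or from the amino nitrogen on the carbonyl carbon, which a 3,5-dimethoxyphenyl group bonded directly to that carbon would help to separate. They also leave open whether a morpholine or a piperazine in place of the dimethylamino group would move the number.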